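Swapping the Aryl Group on a Shared Core

The source may report more compounds than this note shows. Statements on the series, on what has been measured and on what is new or still open speak of the compounds shown alone.

Compound 1 `COc1cc(-n2ncnc2-c2cccc([N+](=O)[O-])c2)cc(OC)c1OC`: in a functional assay on A549 cells (Homo sapiens) for antiproliferative activity, read by MTT assay, with a stated time of 72 h (a higher number here means a weaker inhibitor, a lower number a stronger inhibitor), compound 1 reports only the limit > 10000 nM.
Compound 2 `COc1cc(-n2ncnc2-c2ccc(F)cc2)cc(OC)c1OC`: in this assay compound 2 reports only the limit > 10000 nM.
Compound 3 `COc1cc(-n2ncnc2-c2ccc(C)cc2)cc(OC)c1OC`: in this assay compound 3 gives 1100 nM.

Among the compounds with values here, compound 3 stands as the only compound with a measured number in this assay; the other two values are limits. Within the data shown here, the single measured step that bears on the question is an at least 9.0-fold lower number from compound 2 to compound 3 (0.95 log units; beyond the scatter), behind which sits the limit of > 10000 nM in this assay, at which 2 of the 3 values shown sit, for compound 2. Compound 4 `COc1cc(-n2ncnc2-c2cccc(F)c2)cc(OC)c1OC` differs from compound 3 in that (3-fluorophenyl in place of 4-methylphenyl on an aromatic carbon). Among the measured compounds shown here, the methyl that accompanies the only real number leaves, and a fluoro enters, as on compound 2, though at another position of the phenyl; compound 1 as well sits at the limit. The step is therefore expected to run upward in this assay, in the direction of a weaker inhibitor, with a fair chance that only a limit is reported again. The estimated step is a 7.3-fold higher number from compound 3 to compound 4 (0.86 log units; beyond the scatter). Compound 4 is expected at 8000 nM, within a range of 2500 nM to 25000 nM.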

Compound 4, half-maximal inhibitory concentration: > 10000 nM
Compound 4: only a limit was reported; the forecaster's own chance of this, stated with the estimate: 55%; middle value at least 1.2-fold (0.09 log units) from the limit.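

On the aromatic carbon of the five-membered ring, 3-fluorophenyl in place of 4-methylphenyl gives an at least 9.0-fold higher number from compound 3 to compound 4 (0.95 log units; beyond the scatter) in this assay, so the measurable activity of compound 3 does not survive this exchange. Compound 4 shows that a fluoro at this other position of the phenyl also fails to reach a measured number, though the steps from compound 1 and compound 2 to compound 4 cannot be read, as both ends of each are limits. Among the four compounds, only the 4-methylphenyl group gives a real number, and the others share one limit: the limit of > 10000 nM in this assay, at which 3 of the 4 values shown sit.

As far as these compounds go, it remains open whether the activity depends on the methyl itself or on where it sits, and what 3-methylphenyl would give. Also open, from the compounds shown here alone, is how an ethyl or an amine on the phenyl would compare with the methyl of compound 3.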